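Swapping the hydroxyphenyl for a chlorobenzyl: expected cytotoxicity

This account rests on a few compounds, and the source may have more. Where it says the series, first, only, none or still open, it means among the compounds named here.

Three compounds have so far been tested in an ADME assay on L02 cells (Homo sapiens) for cytotoxicity, read by MTT assay; on this read-out higher numbers stand for weaker inhibition and lower numbers for stronger inhibition:
compound 1 `COc1ccc(Nc2nc(/C=C/c3cc(OC)c(OC)c(OC)c3)nc3ccsc23)cc1` gives 279000 nM
compound 2 `COc1cc(/C=C/c2nc(Nc3ccc(C(F)(F)F)cc3)c3sccc3n2)cc(OC)c1OC` gives 436000 nM
compound 3 `COc1cc(/C=C/c2nc(Nc3ccc(O)cc3)c3sccc3n2)cc(OC)c1OC` gives 2300000 nM

Compound 3 stands at the top of these three numbers, that is, it is the weakest inhibitor of the cells. Its gap to the other two is beyond the scatter: an 8.2-fold higher number from compound 1 to compound 3 (0.92 log units; beyond the scatter) and a 5.3-fold higher number from compound 2 to compound 3 (0.72 log units; beyond the scatter). Between compound 1 and compound 2 the gap is within the scatter, a 1.6-fold higher number from compound 1 to compound 2 (0.19 log units; within the scatter).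

Compound 4 `COc1cc(/C=C/c2nc(NCc3ccc(Cl)cc3)c3sccc3n2)cc(OC)c1OC` is not yet measured. The change from compound 3 is 4-chlorobenzyl in place of 4-hydroxyphenyl on a nitrogen on an aromatic ring. Going by the values given here, what the data speak to is the loss of the hydroxy group: compound 3 is the only compound carrying it, and it is also the only one standing apart, while compound 1 and compound 2, which carry a methoxy or a trifluoromethyl in its place, sit close together. Compound 4 also lacks the hydroxy group, so a return toward the numbers of compound 1 and compound 2 is expected. The extra carbon between the nitrogen and the ring has no parallel among the measured compounds, so the expected step is stated with a broad range: a 5.1-fold lower number from compound 3 to compound 4 (0.71 log units; beyond the scatter). Compound 4 is thus estimated at 450000 nM, with a range from 150000 nM to 1500000 nM.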

Compound 4, half-maximal inhibitory concentration: 4320000 nM
Beside the measured number, compound 4's estimate is 9.6-fold (0.98 log units) below it, and the stated range ends below it.
By their numbers in this assay, from the lowest: compounds 1 and 2 (each within the scatter of the next); then compounds 3 and 4 (each within the scatter of the next).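

In this assay, putting 4-chlorobenzyl in place of 4-hydroxyphenyl on this nitrogen gives a number that cannot be told apart from that of the hydroxy compound (a 1.9-fold higher number from compound 3 to compound 4 (0.27 log units; within the scatter)), so the hydroxy group is not the only feature that goes with the high numbers in this set. Compound 4 lacks the hydroxy group, yet it stands clearly apart from the compounds with 4-(trifluoromethyl)phenyl (a 9.9-fold higher number from compound 2 to compound 4 (1.00 log units; beyond the scatter)) and 4-methoxyphenyl (a 15-fold higher number from compound 1 to compound 4 (1.19 log units; beyond the scatter)) at this position, which shows that the group on this nitrogen can move the number even when no hydroxy group is present. Nothing available here explains why the numbers fall this way.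

The change from 4-hydroxyphenyl to 4-chlorobenzyl brings in the benzyl link and the chlorine and removes the hydroxy group all at once, so these compounds cannot show which of those parts goes with the number, whereas a 4-chlorophenyl or a 4-hydroxybenzyl group on this nitrogen would help to separate them. Also open, as far as these compounds go, is where a benzyl group carrying a carboxylic acid, or a longer chain on this nitrogen, would fall.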